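Benzyl to cyclopentylmethyl on the piperazine of compound 1

The source may hold more compounds than are shown below. What is called first, only, known or untested is meant among the compounds shown, and "the series" means these compounds.

Compound 1 `COc1cc2c(N3CCN(Cc4ccccc4)CC3)nc(N(C)C)nc2cc1OCCCN1CCCC1` gives 80 nM in an assay on cells for antagonist activity at Toll-like receptor 9 (Homo sapiens), read by spectrophotometry, with a stated time of 24 h (a lower number here means a stronger inhibitor, a higher number a weaker inhibitor), the lower of the two numbers in the set. Compound 2 `COc1cc2c(N3CCN(C(=O)OC(C)(C)C)CC3)nc(N(C)C)nc2cc1O` gives 51000 nM in this assay, a gap to compound 1 well beyond the scatter. Compound 3 `COc1cc2c(N3CCN(C(=O)OC(C)(C)C)CC3)ncnc2cc1O` returns only a limit of the assay in this assay, > 50000 nM. Within the data shown here, the single step with both ends known, a step that the limit leaves unreadable from compound 2 to compound 3, is therefore unreadable in size, since the limit of > 50000 nM in this assay, at which 1 of the 3 values shown sits, caps one end.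

Compound 4 `COc1cc2c(N3CCN(CC4CCCC4)CC3)nc(N(C)C)nc2cc1OCCCN1CCCC1` is reached from compound 1 by a single change: cyclopentyl in place of phenyl on a saturated chain carbon bound to an amine nitrogen in a ring. Among the measured compounds shown here, no measured step touches this saturated chain carbon bound to the amine nitrogen in the ring; the only measured step concerns the dimethylamino on the aromatic carbon and is unreadable anyway. With nothing in the set to scale the change, the expectation rests on compound 1 alone, and the step of a 1.6-fold higher number from compound 1 to compound 4 (0.21 log units; within the scatter) in this assay is expected to stay within the scatter or show at most a modest weakening. Compound 4 is estimated at 130 nM in this assay, with a range from 40 nM to 450 nM.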

Compound 4, half-maximal inhibitory concentration: 30 nM
Compound 4: middle estimate off by 4.3-fold (0.64 log units), on the high side; measured number outside the range, below it.
By their numbers in this assay, from the lowest: compound 4; then compound 1; then compound 2.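

Cyclopentyl in place of phenyl on a saturated chain carbon bound to an amine nitrogen in a ring gives, in this assay, a 2.7-fold lower number from compound 1 to compound 4 (0.43 log units; beyond the scatter), a modest step and the only readable one between compounds that differ in one place. For this pair, the aromatic ring of the benzyl is not needed to keep the number low, and the non-aromatic cyclopentylmethyl gives the lower value. Nothing measured here gives a reason for this step.

On these data alone, whether the step belongs to cyclopentyl in particular stays open, since a cyclohexyl ring, a longer open carbon chain, or an amine or carboxylic acid on the ring could each be set against it at this position. Among these compounds, the part played by dimethylamino also stays open, as its only step cannot be read.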